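Notes on the aromatic group of the series

The source may hold more compounds than are shown below. What is called first, only, known or untested is meant among the compounds shown, and "the series" means these compounds.

- compound 1 `CC1(C)CCC[C@]2(C)[C@@H](CC[C@@](C)(O)/C=C/c3cccc([N+](=O)[O-])c3)[C@](C)(O)CC[C@@H]12`: 153 nM
- compound 2 `CC1(C)CCC[C@]2(C)[C@@H](CC[C@@](C)(O)/C=C/c3ccc(Cl)nc3)[C@](C)(O)CC[C@@H]12`: 275 nM

Going by the values given here, in a functional assay on PC-3 cells (Homo sapiens) for cytotoxicity, read by MTT assay, with a stated time of 48 h (a higher number here means a weaker inhibitor, a lower number a stronger inhibitor), compound 2 gives 275 nM, which lies within the scatter of its only neighbour, compound 1. Compound 3 `COc1cccc(/C=C/[C@](C)(O)CC[C@@H]2[C@@]3(C)CCCC(C)(C)[C@@H]3CC[C@@]2(C)O)c1OC` keeps the shared core and differs from compound 2 as follows: 2,3-dimethoxyphenyl in place of 6-chloropyridin-3-yl on a double-bonded chain carbon bound to a double-bonded chain carbon. Among the compounds with values here, one measured step bears on this change, made at the same place: a 1.8-fold higher number from compound 1 to compound 2 (0.25 log units; within the scatter). Within the data shown here, on that single step, no change beyond the scatter is expected in this assay, although no measured compound carries a 2,3-dimethoxyphenyl group. The expected step is a 1.1-fold lower number from compound 2 to compound 3 (0.04 log units; within the scatter). Compound 3 is estimated at 250 nM, with a range of 90 nM to 700 nM.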

Compound 3, half-maximal inhibitory concentration: 2900 nM
Estimate against measurement, compound 3: 12-fold (1.06 log units) below; measured number outside the range, above it.
By their numbers in this assay, from the lowest: compounds 1 and 2 (each within the scatter of the next); then compound 3.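

In this assay, the aromatic group at this place, on a double-bonded chain carbon bound to a double-bonded chain carbon, clearly matters: 2,3-dimethoxyphenyl gives an 11-fold higher number from compound 2 to compound 3 (1.02 log units; beyond the scatter) and a 19-fold higher number from compound 1 to compound 3 (1.28 log units; beyond the scatter). The earlier pair, 3-nitrophenyl and 6-chloropyridin-3-yl, lay within the scatter of each other and showed no such sensitivity. Nothing available explains this step.

Going by these compounds, whether both methoxy groups are needed for the step, or one alone would produce it, remains open. Also open, on these data alone, is how a phenyl ring carrying an amine or a carboxylic acid would read at this place.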